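Dropping the Acid: Reversed Amide in Compound 4

The source may hold more compounds than are shown below. What is called first, only, known or untested is meant among the compounds shown, and "the series" means these compounds.

Compound 1 `NCc1ccc(C(=O)Nc2ccncc2F)cc1-c1cccc(NC(=O)c2cccc(C(=O)O)c2)c1` was tested in an assay on cells for inhibition of Rho-associated protein kinase 2 (Homo sapiens), read by radiometric assay and 33P incorporation, in the presence of a further agent that is not named here; on this read-out higher numbers stand for weaker inhibition and lower numbers for stronger inhibition. In this assay compound 1 gives < 1 nM, which is a limit of the assay rather than a number. Compound 2 `CCCOC(=O)c1ccc(NC(=O)c2cccc(-c3cc(C(=O)Nc4ccncc4F)ccc3CN)c2)cc1` also gives < 1 nM, again a limit. Compound 3 `NCc1ccc(C(=O)Nc2ccncc2F)cc1-c1cccc(NC(=O)c2ccc(C(=O)O)cc2)c1` gives 1 nM. The step of a number no lower from compound 1 to compound 3 (the limit leaves the size open) cannot be sized because of the limit of < 1 nM in this assay, at which 2 of the 3 values shown sit. Compound 1 thus sits where the assay stops reporting numbers. Compound 4 `NCc1ccc(C(=O)Nc2ccncc2F)cc1-c1cccc(C(=O)Nc2ccccc2)c1` differs from compound 1 by phenylcarbamoyl in place of ((3-carboxyphenyl)carbonyl)amino on an aromatic carbon. Within the data shown here, no measured step touches this part of the molecule, so the measured compounds give no guide to the direction of this change. Compound 4 is expected to give about 6 nM, within a range from 1 nM to 50 nM. The expected step is an at least 6.0-fold higher number from compound 1 to compound 4 (0.77 log units; beyond the scatter).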

Compound 4, half-maximal inhibitory concentration: < 1 nM
Compound 4: a limit, no number; the forecaster's own chance of this, stated with the estimate: 20%; middle value at least 6.0-fold (0.77 log units) away from the limit.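

In this assay compound 4 gives < 1 nM, a limit and not a number. Phenylcarbamoyl, which carries no carboxylic acid, therefore still reaches the limit at this position, and the change gives a number no higher from compound 3 to compound 4 (the limit leaves the size open). The steps from compound 1 and compound 2 cannot be read because both ends are limits: the limit of < 1 nM in this assay, at which 3 of the 4 values shown sit.

On these data alone, how far compound 1, compound 2 and compound 4 truly differ stays open. Also open, as far as these compounds go, is whether an amine or a longer chain on the phenyl ring of phenylcarbamoyl would keep this level.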